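A Side-Chain Swap at the Edge of the Assay

The source may hold more compounds than are shown below. What is called first, only, known or untested is meant among the compounds shown, and "the series" means these compounds.

Compound 1 `CCOC(=O)C(=O)CC(=O)/C=C/c1cn(CCC(C)C)c2ccccc12` has the entry "not determined" (no result reported) in an ADME assay on HeLa cells (Homo sapiens) for inhibition, read by MTT assay, with a stated time of 48 h (on this read-out lower numbers stand for stronger inhibition and higher numbers for weaker inhibition), so it offers no number to build on. Compound 2 `CC(C)CCn1cc(/C=C/C(=O)CC(=O)C(=O)O)c2ccccc21` reads > 80000 nM in this assay, which is a limit of the assay and not a number. Compound 2 therefore stands at the limit of > 80000 nM in this assay, at which 1 of the 2 values shown sits.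

Compound 3 `CN(C)C(=O)Cn1cc(/C=C/C(=O)CC(=O)C(=O)O)c2ccccc21` keeps the shared core of compound 2 and differs in one place, a saturated chain carbon bound to an aromatic nitrogen. There, dimethylcarbamoyl stands in place of isobutyl (dimethylcarbamoyl in place of isobutyl on a saturated chain carbon bound to an aromatic nitrogen). Cut one bond further out, the same change reads isopentyl to (dimethylcarbamoyl)methyl.

Among the compounds with values here, no pair of measured compounds shows what a change of this kind does in this assay, so any forecast here is cautious. The expected step that the limit leaves unreadable from compound 2 to compound 3 is no larger than the usual scatter, and no direction can be favoured. Most likely the assay will again report only a limit. If a number does appear, the estimated value for compound 3 is 100000 nM, with an expected range from 40000 nM to 250000 nM.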

Compound 3, half-maximal inhibitory concentration: > 40000 nM
Compound 3 ended at the assay's limit (the forecaster's own chance of this, stated with the estimate: 70%); the middle value is on the limit's open side.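

Within the data shown here, compound 2 and compound 3 both end at limits of this assay and not at numbers, and no step between the two can be read from them. The compounds shown leave open whether dimethylcarbamoyl in place of isobutyl on a saturated chain carbon bound to an aromatic nitrogen changes inhibition at all, and in which direction.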